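This account rests on a few compounds, and the source may have more. Where it says the series, first, only, none or still open, it means among the compounds named here.

Measured compounds:
- Compound 1, `CCOC(=O)C1CCN(C(=O)c2cc(-c3ccc(C)cc3)nn2Cc2ccccc2)CC1`, in a functional assay on the whole organism (strain Swiss albino) for inhibition, with Mus musculus as the target, read by paw edema, with stated times of 30 min and 90 min, at a dose of 100 mg/kg by the subcutaneous route; on this read-out lower numbers stand for less inhibition and higher numbers for more inhibition at the one dose given (going by the name of the read-out): 26.7%
- Compound 2, `Cc1ccc(-c2cc(C(=O)NCc3cccnc3)n(Cc3ccccc3)n2)cc1`, in this assay: 3.7%

Of the two numbers recorded in this assay, compound 2 stands lowest; its nearest neighbour is compound 1, whose inhibition is higher by an amount that lies beyond the usual scatter of this kind of measurement. Within the data shown here, no pair of measured compounds differs in a single place, so no step within the set can be drawn on.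

Compound 3, `Cc1ccc(-c2cc(C(=O)NNc3ccc4ccccc4n3)n(Cc3ccccc3)n2)cc1`, has not yet been measured in this assay. It differs from compound 2 in one place: (quinolin-2-yl)amino in place of (pyridin-3-yl)methyl on an amide-type nitrogen. Among the measured compounds shown here, since no measured step involves this change, the direction of its effect cannot be read from the data. Given that compound 2 gives 3.7% in this assay, and that the whole set spans only a modest range, compound 3 is expected to show a step of a number 10.3 percentage points higher from compound 2 to compound 3 (beyond the scatter), a small rise that may not exceed the scatter. The estimate for compound 3 in this assay is 14%, with a range from 0% to 32%.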

Compound 3, a percentage reported as inhibition, in the whole organism at one dose (the size of the read-out at that dose, not a potency): 23%
Compound 3: the middle estimate sits 9 percentage points below what was measured, within the range that was stated.
By their numbers in this assay, from the lowest: compound 2; then compounds 3 and 1 (each within the scatter of the next).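

In this assay, the group on the amide-type nitrogen proves able to shift the read-out: putting (quinolin-2-yl)amino in place of (pyridin-3-yl)methyl gives a number 19.3 percentage points higher from compound 2 to compound 3 (beyond the scatter), the first step seen at this place. The exchange alters several features at once, since the entering group is larger and brings in a carbon-only aromatic ring and a hydrogen-bond donor that the leaving group lacks, so the step cannot be assigned to any one of these features. Nothing in the data available here bears on why the inhibition rises.

On these data alone, it remains open whether the rise follows the added carbon-only ring or the nitrogen that joins the ring system to the amide-type nitrogen; a phenylamino group or a (quinolin-2-yl)methyl group at this place would separate the two. As far as these compounds go, it is also open how the change behaves at other doses or with other groups on the shared core, such as a carboxylic acid or a longer chain in place of the benzyl group, as this single step rests on one dose and one pair of compounds.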